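A few compounds are considered here, and "the series" means these few. Any claim that something is new, unique, unknown or untested is made for them only; others in the source may bear on it.

Within the data shown here, compound 2 `CC(=O)OC[C@H]1O[C@@H](n2[se]c3ccccc3c2=O)[C@H](OC(C)=O)[C@@H](OC(C)=O)[C@@H]1OC(C)=O` gives 19000 nM in a functional assay on NCI-H1299 cells (Homo sapiens) for cytotoxicity, read by resazurin assay, with a stated time of 48 h (on this read-out higher numbers stand for weaker inhibition and lower numbers for stronger inhibition), the highest of the two numbers so far; its nearest neighbour is compound 1 `CC(=O)O[C@@H]1[C@@H](OC(C)=O)[C@H](OC(C)=O)CO[C@H]1n1[se]c2ccccc2c1=O`, which gives 7000 nM. Among the measured compounds shown here, the single measured step, a 2.7-fold higher number from compound 1 to compound 2 (0.43 log units; beyond the scatter), concerns an added group rather than configuration. Compound 3 `CC(=O)OC[C@H]1O[C@@H](n2[se]c3ccccc3c2=O)[C@H](OC(C)=O)[C@@H](OC(C)=O)[C@H]1OC(C)=O` differs from compound 2 as follows: the two compounds have the same atoms and bonds and differ only in configuration as drawn: 1 of 5 stereo elements differ; a stereocentre at a saturated ring carbon is drawn R in compound 2 and S in compound 3. For the measured compounds named here, no measured step bears on the inversion of one stereocentre, so the expectation is no shift beyond the scatter, with a wide margin of uncertainty, no change at the digits printed from compound 2 to compound 3 (within the scatter). Compound 3 is therefore estimated at 19000 nM, within a range of 8000 nM to 45000 nM.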

Compound 3, half-maximal inhibitory concentration: 21600 nM
The estimate for compound 3 lay 1.1-fold (0.06 log units) below the measured number; the range from low to high includes it.
By their numbers in this assay, from the lowest: compound 1; then compounds 2 and 3 (each within the scatter of the next).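

Inverting one stereocentre at a saturated ring carbon gives a 1.1-fold higher number from compound 2 to compound 3 (0.06 log units; within the scatter) in this assay. The earlier step concerned only the added acetoxymethyl, whereas this pair isolates configuration at a single position, and the read-out does not separate R from S there. The comparison is confined to one feature: the fact that compounds 2 and 3 differ only in the configuration as drawn

The compounds shown leave open how inversion at the other stereocentres would read, and whether an amine in place of an acetoxy group on the saturated ring would shift the number.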